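The source may report more compounds than this note shows. Statements on the series, on what has been measured and on what is new or still open speak of the compounds shown alone.

Compound 1 `COc1cc(COc2ccc(C(=O)N/N=C/c3cc(Br)cc(Cl)c3O)cc2)cc(OC)c1OC` was tested in a physicochemical assay, with a stated time of 30 min (on this read-out higher numbers stand for weaker inhibition and lower numbers for stronger inhibition), and in this assay compound 1 gives > 100 ug/mL, which is a limit of the assay rather than a number. Compound 2 `COc1cc(/C=N/NC(=O)c2ccc(OCc3cc(OC)c(OC)c(OC)c3)cc2)cc(OC)c1OC` gives > 100 ug/mL in this assay, again a limit. Compound 3 `COc1cc(COc2ccc(C(=O)N/N=C/c3cccc(O)c3)cc2)cc(OC)c1OC` gives > 100 ug/mL in this assay, also a limit. The steps a step that the two limits leave unreadable from compound 1 to compound 2, a step that the two limits leave unreadable from compound 1 to compound 3 and a step that the two limits leave unreadable from compound 2 to compound 3 cannot be read in size because of the limit of > 100 ug/mL in this assay, at which 3 of the 3 values shown sit. Compound 4 `COc1cc(COc2ccc(C(=O)N/N=C/c3ccc(O)cc3)cc2)cc(OC)c1OC` differs from compound 1 in one place: 4-hydroxyphenyl in place of 5-bromo-3-chloro-2-hydroxyphenyl on a carbon with a double bond to nitrogen. The measured steps that bear on this change are the two leading away from compound 1, each of which replaces the group on the same carbon with a double bond to nitrogen, and each of which stayed at the limit. Nothing in these numbers points to a readable step in either direction. Compound 4 is expected to show 150 ug/mL, with a range from 60 ug/mL to 400 ug/mL. The step that the limit leaves unreadable from compound 1 to compound 4 is therefore expected to stay within the limit rather than appear as a measurable change.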

Compound 4, half-maximal inhibitory concentration: > 100 ug/mL
Compound 4: only a limit was reported; the forecaster's own chance of this, stated with the estimate: 80%; the middle value does not contradict the limit.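

In this assay compound 4 gives > 100 ug/mL, a limit rather than a number, so its steps to compound 1, compound 2 and compound 3 cannot be read in size: the limit of > 100 ug/mL in this assay, at which 4 of the 4 values shown sit. The compounds shown leave open how strongly any of them inhibits, and whether changing the group on the carbon with a double bond to nitrogen alters that at all.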